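The source may report more compounds than this note shows. Statements on the series, on what has been measured and on what is new or still open speak of the compounds shown alone.

Compound 3 `O=C(O)c1ccccc1-c1ccc(CCc2ncc(C3CCCCC3)[nH]2)cc1` gives the lowest number of the three in an in vitro functional assay on cells for agonist activity at Bombesin receptor subtype-3 (Homo sapiens), read by luminescence and calcium flux (on this read-out higher numbers stand for an effect only at larger amounts of compound and lower numbers for an effect already at smaller amounts), at 375 nM. Compound 1 `CCCCc1cnc(C(CCC)Cc2ccc(-c3ccccc3C(=O)O)cc2)[nH]1` gives 1180 nM, and compound 2 `CCCCc1cnc(CCCc2ccc(-c3ccccc3C(=O)O)cc2)[nH]1` gives 5600 nM. Both of these numbers lie beyond the scatter above that of compound 3, the number of compound 1 nearer to it and that of compound 2 farthest from it. Compound 4 `Cc1cccc(Cc2cnc(CCc3ccc(-c4ccccc4C(=O)O)cc3)[nH]2)c1` has not yet been measured. It differs from compound 3 in one place: 3-methylbenzyl in place of cyclohexyl on an aromatic carbon. Going by the values given here, no measured pair shows this change, so its size cannot be read from the data. A modest rise in the number is expected, a 1.6-fold higher number from compound 3 to compound 4 (0.20 log units; within the scatter), though a step of none beyond the scatter remains possible. Compound 4 is estimated at 600 nM in this assay, with a range from 120 nM to 3000 nM.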

Compound 4, half-maximal effective concentration: 4310 nM
Beside the measured number, compound 4's estimate is 7.2-fold (0.86 log units) below it; the whole stated range lies below it.
By their numbers in this assay, from the lowest: compound 3; then compound 1; then compounds 4 and 2 (each within the scatter of the next).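

Going by these compounds alone, on this aromatic carbon of the five-membered ring, the first single-place comparison shows a strong dependence on the group carried: in this assay 3-methylbenzyl in place of cyclohexyl gives an 11-fold higher number from compound 3 to compound 4 (1.06 log units; beyond the scatter) with no hydrogen-bond donor or acceptor entering or leaving. The entering group is an aromatic ring with 8 heavy atoms, against a non-aromatic ring with 6, so ring type and size change together. No measurement shown gives a cause for this step.

The compounds shown do not separate the contributions of the ring type, the methyl and the carbon link. Plain benzyl, phenyl or cyclopentyl at this position remains open.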